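The compounds below may be only part of what the source reports. "The series", "measured", "known", "first", "only" and "open" are said of these compounds alone.

Compound 1 `CC(C)(C)c1sc2ncnc(Oc3ccccc3F)c2c1-c1ccc(F)cc1` and compound 2 `CC(C)(C)c1sc2ncnc(Oc3ccccc3OC(F)(F)F)c2c1-c1ccc(F)cc1` share one core and differ in a single group. In an ADME assay on microsomes from liver (Homo sapiens) for metabolic stability, read by LC-MS, using NADPH, with a stated time of 30 min (a lower number here means that less of the compound is left, a higher number that more of the compound is left), compound 1 gives > 95%, which is a limit of the assay and not a number. Compound 2 gives > 95%, also a limit, so it stands at the top of the readable range, with no exact number to its name. Going by the values given here, the same holds across the series so far: the limit of > 95% in this assay, at which 2 of the 2 values shown sit.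

Compound 3 `CC(C)(C)c1sc2ncnc(Oc3ccccc3OC(F)(F)F)c2c1-c1ccc(Cl)c(Cl)c1` keeps the trifluoromethoxy group of compound 2 and changes the other aryl group: 3,4-dichlorophenyl in place of 4-fluorophenyl on an aromatic carbon. In words, 3,4-dichlorophenyl stands in place of 4-fluorophenyl on an aromatic carbon, next to the ring atom that bears a tert-butyl group.

Among the compounds with values here, only one measured step exists, a step that the two limits leave unreadable from compound 1 to compound 2. It concerns a different group, and its size cannot be read, so it offers no size to carry over. No step beyond the scatter is therefore expected in this assay, though a small downward move remains possible. The expected change is a number at least 3 percentage points lower from compound 2 to compound 3 (that floor lies within the scatter). For compound 3 the estimated value is 92%, with an expected range from 75% to 100%.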

Compound 3, percent of the compound remaining: > 95%
Compound 3: only a limit was reported (the forecaster's own chance of this, stated with the estimate: 50%); middle value at least 3 percentage points away from the limit.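

In this assay compound 3 gives > 95%, which is a limit of the assay and not a number. Compound 2 also sits at a limit, so no step from compound 2 to compound 3 can be read: the limit of > 95% in this assay, at which 3 of the 3 values shown sit.

The compounds shown leave open whether exchanging 4-fluorophenyl for 3,4-dichlorophenyl changes the percent of compound remaining at all, and by how much.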